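Neopentyl for Phenyl, Carried from One Core to Another

A few compounds are considered here, and "the series" means these few. Any claim that something is new, unique, unknown or untested is made for them only; others in the source may bear on it.

Compound 1 `O=C(NCc1cc(Cl)ccc1-n1cnnn1)[C@@H]1C[C@H]2C[C@H]2N1C(=O)[C@H](O)c1ccccc1` and compound 2 `CC(C)(C)C[C@@H](O)C(=O)N1[C@@H]2C[C@@H]2C[C@H]1C(=O)NCc1cc(Cl)ccc1-n1cnnn1` share one core, and in a functional assay on a cell-free system (plasma, Homo sapiens), with a stated time of 3 min (on this read-out higher numbers stand for weaker inhibition and lower numbers for stronger inhibition), compound 1 gives 680 nM while compound 2 gives 520 nM. The change between them, (neopentyl in place of phenyl on a saturated chain carbon bound to a carbonyl carbon and an oxygen on a saturated carbon), produced a 1.3-fold lower number from compound 1 to compound 2 (0.12 log units; within the scatter). Compound 3 `O=C(NCc1cc(Cl)ccc1-n1cnnn1)[C@@H]1CCON1C(=O)[C@H](O)c1ccccc1` rests on a different core; the difference between the two cores is not broken down here. In this assay compound 3 gives 1500 nM, the highest of the three numbers, with its steps to compound 1 and compound 2 both beyond the scatter. Compound 4 `CC(C)(C)C[C@@H](O)C(=O)N1OCC[C@H]1C(=O)NCc1cc(Cl)ccc1-n1cnnn1` has not been measured; it differs from compound 3 by neopentyl in place of phenyl on a saturated chain carbon bound to a carbonyl carbon and an oxygen on a saturated carbon, the same change that links compound 1 and compound 2, occurring twice among these compounds. Because that earlier change gave a 1.3-fold lower number from compound 1 to compound 2 (0.12 log units; within the scatter), compound 4 is expected to show about a 1.3-fold lower number from compound 3 to compound 4 (0.12 log units; within the scatter) relative to compound 3. Compound 4 is therefore estimated at 1150 nM, between 500 nM and 2600 nM.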

Compound 4, half-maximal inhibitory concentration: 1100 nM
The estimate for compound 4 lay 1.0-fold (0.02 log units) above the measured number; the measured number falls inside the stated range.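

In this assay neopentyl in place of phenyl gives a 1.4-fold lower number from compound 3 to compound 4 (0.13 log units; within the scatter) and so matches what the same change does on the core of compound 1: the same change on two cores in this assay, a 1.3-fold lower number (0.12 log units; within the scatter) from compound 1 to compound 2 and a 1.4-fold lower number (0.13 log units; within the scatter) from compound 3 to compound 4, 1.0-fold (0.02 log units) apart, within the scatter of two such steps. What carries over from one core to the other is a step too small to resolve, not a shown gain in inhibition. Two cores also say nothing about how the change would behave on any other core in this series.

The compounds shown leave open whether another group in the same place, such as an amine, a carboxylic acid or a longer chain, would move the number beyond the scatter on either core. They also leave open which feature of the cores separates compound 3 from compound 1.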